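From methoxy to cyclobutyloxy: a clearance estimate for compound 3

A few compounds are considered here, and "the series" means these few. Any claim that something is new, unique, unknown or untested is made for them only; others in the source may bear on it.

Compound 1 `CCOc1ncc(-c2nc(C(F)(F)F)sc2N2CCN(C(=O)Cn3nccc3C)[C@H](C)C2)cn1`: 65 mL.min-1.g-1
Compound 2 `COc1ncc(-c2nc(C(F)(F)F)sc2N2CCN(C(=O)Cn3nc(C)nc3C)[C@H](C)C2)cn1`: < 10 mL.min-1.g-1

In a toxicity assay on microsomes from liver (Homo sapiens) for metabolic stability, read by LC-MS, using NADPH, tested at 1 uM (a lower number here means slower removal, a higher number faster removal of the compound), compound 2 gives < 10 mL.min-1.g-1, which is a limit of the assay and not a number. Among the compounds with values here, it is the one compound of the pair that stands at this limit: the limit of < 10 mL.min-1.g-1 in this assay, at which 1 of the 2 values shown sits. Compound 1 has a true reading of 65 mL.min-1.g-1, so it is removed faster.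

Compound 3 `Cc1nc(C)n(CC(=O)N2CCN(c3sc(C(F)(F)F)nc3-c3cnc(OC4CCC4)nc3)C[C@H]2C)n1` has not yet been measured. It carries cyclobutyl in place of methyl on an oxygen on an aromatic ring, so that 2-methoxypyrimidin-5-yl becomes 2-(cyclobutyloxy)pyrimidin-5-yl: cyclobutyl in place of methyl on an oxygen on an aromatic ring.

Within the data shown here, no measured pair shows this change alone, so the size of the step is a judgement. Among the measured compounds shown here, the only true number available as a guide is that of compound 1, at 65 mL.min-1.g-1. The expected step is an at least 3.5-fold higher number from compound 2 to compound 3 (0.54 log units; beyond the scatter), towards faster removal and larger than the usual scatter. In this assay, the estimated value for compound 3 is 35 mL.min-1.g-1, with an expected range of 14 mL.min-1.g-1 to 90 mL.min-1.g-1.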

Compound 3, intrinsic clearance in microsomes: 51 mL.min-1.g-1
For compound 3 the middle estimate is 1.5-fold (0.16 log units) below the measured one; measured number inside the range.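

Before compound 3, the compounds shown offered no step that changes one place only, so nothing could be said about the group on this oxygen by itself. With cyclobutyl in place of methyl on an oxygen on an aromatic ring, and the rest of the molecule untouched, this assay shows an at least 5.1-fold higher number from compound 2 to compound 3 (0.70 log units; beyond the scatter), a move towards faster removal that lies beyond the usual scatter, so this position clearly matters for the read-out. Compound 2 stands at a limit of the assay and not at a number, so this step has only a lower bound and its full size stays unknown: the limit of < 10 mL.min-1.g-1 in this assay, at which 1 of the 3 values shown sits.

As far as these compounds go, a single step cannot tell whether the ring of cyclobutyl counts or merely the larger group on the oxygen, and what an open chain such as isopropyl or n-butyl would do in the same place remains open. Compound 1, with its ethoxy group, differs from compound 2 in a second place as well, so it cannot settle this question.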